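Swapping the chlorophenyl arm for a phenylethenyl chain

The source may report more compounds than this note shows. Statements on the series, on what has been measured and on what is new or still open speak of the compounds shown alone.

Of the compounds shown here, two built on a shared core have been tested so far: compound 1 `Cc1cc(O)c(C2=NN(c3ccc(S(N)(=O)=O)cc3)C(c3ccccc3O)C2)cc1Cl` and compound 2 `Cc1cc(O)c(C2=NN(c3ccc(S(N)(=O)=O)cc3)C(c3ccccc3Cl)C2)cc1Cl`. In a functional assay on the whole organism (strain Wistar) for inhibition, with Rattus norvegicus as the target, read by paw edema, with stated times of 30 min and 3 h, at a dose of 20 mg/kg by the oral route (a lower number here means less inhibition, a higher number more inhibition at the dose given (going by the name of the read-out)), compound 1 gives 73.6%, while compound 2 gives 55.3%. Within the data shown here, the single measured step, a number 18.3 percentage points lower from compound 1 to compound 2 (beyond the scatter), is the change from hydroxy to chloro on the aromatic ring attached to the saturated ring carbon. On these two numbers compound 2 stands lowest, with compound 1 above it beyond the scatter.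

Compound 3 `Cc1cc(O)c(C2=NN(c3ccc(S(N)(=O)=O)cc3)C(/C=C/c3ccccc3)C2)cc1Cl` differs from compound 2 in one place: 2-phenylethenyl in place of 2-chlorophenyl on a saturated ring carbon. Among the measured compounds shown here, the only measured step concerns a substituent on the same aromatic ring and does not show what replacing that ring by a 2-phenylethenyl chain does, so it is a weak guide. The expected step is therefore a number 2.7 percentage points higher from compound 2 to compound 3 (within the scatter), no change beyond the scatter in this assay. Compound 3 is estimated at 58%, between 40% and 76%.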

Compound 3, a percentage reported as inhibition, in the whole organism at one dose (the size of the read-out at that dose, not a potency): 78.9%
The estimate for compound 3 lay 20.9 percentage points below the measured number, and the stated range ends below it.
By their numbers in this assay, from the lowest: compound 2; then compounds 1 and 3 (each within the scatter of the next).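

In this assay the change from 2-chlorophenyl to 2-phenylethenyl on the saturated ring carbon gives a number 23.6 percentage points higher from compound 2 to compound 3 (beyond the scatter) and shows that this position can carry a chain with a double bond without any loss against the other arms. Measured against the 2-hydroxyphenyl arm, the same chain gives a number 5.3 percentage points higher from compound 1 to compound 3 (within the scatter) and so leaves compound 1 and compound 3 level, which makes compound 2 the only one of the three set apart. No measurement at hand bears on the reason for this result.

As far as these compounds go, what a saturated 2-phenylethyl chain would give at this carbon remains open, and with it the part played by the double bond. Also open, from the compounds shown here alone, is whether the phenyl end of the chain is needed at all, which a plain propyl chain or a carboxylic acid in its place would test.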